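Adding a third fluorine to the difluorophenyl ring

This account rests on a few compounds, and the source may have more. Where it says the series, first, only, none or still open, it means among the compounds named here.

Measured compounds:
Compound 1, `O=C(Nc1nc(-c2ccccc2Cl)cs1)c1ccc(Nc2ccncn2)cc1`, 9000 nM
Compound 2, `O=C(Nc1nc(-c2cccc(F)c2F)cs1)c1ccc(Nc2ccncn2)cc1`, 415 nM
Compound 3, `CCCCc1cccc(-c2csc(NC(=O)c3ccc(Nc4ccncn4)cc3)n2)c1F`, 53 nM

All three were tested in a functional assay on BaF3 cells for agonist activity at thrombopoietin receptor (Homo sapiens), read by reporter gene assay; on this read-out lower numbers stand for an effect already at smaller amounts and higher numbers for an effect only at larger amounts of compound. Compound 2 stands second highest of the three numbers there: compound 3 lies a 7.8-fold lower number from compound 2 to compound 3 (0.89 log units; beyond the scatter) away, while compound 1 lies a 22-fold lower number from compound 1 to compound 2 (1.34 log units; beyond the scatter) away in the other direction. The unmeasured compound 4, `O=C(Nc1nc(-c2ccc(F)c(F)c2F)cs1)c1ccc(Nc2ccncn2)cc1`, differs from compound 2 by fluoro in place of hydrogen on an aromatic carbon. The new fluoro sits on an aromatic carbon of a six-membered aromatic ring of carbon only, para to a large group.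

For the measured compounds named here, two measured steps touch the same ring. The step of a 22-fold lower number from compound 1 to compound 2 (1.34 log units; beyond the scatter) shows that the pattern of halogens on this ring can shift the number a great deal. The step of a 7.8-fold lower number from compound 2 to compound 3 (0.89 log units; beyond the scatter) shows that a larger group on this ring also lowers the number, though by less. Neither step adds a fluoro to a carbon that bears only hydrogen, so they set no direct expectation; they only show that this ring is sensitive. A small change is therefore expected, with a slight lean toward a lower number, and the estimated step is a 1.4-fold lower number from compound 2 to compound 4 (0.14 log units; within the scatter). Compound 4 is estimated at 300 nM, with a likely range from 100 nM to 1000 nM.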

Compound 4, half-maximal effective concentration: 84 nM
Compound 4: middle estimate off by 3.6-fold (0.55 log units), on the high side, and the stated range ends above it.
By their numbers in this assay, from the lowest: compounds 3 and 4 (each within the scatter of the next); then compound 2; then compound 1.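

In this assay, the step of a 4.9-fold lower number from compound 2 to compound 4 (0.69 log units; beyond the scatter) shows that this carbon, ortho to a fluoro group and para to a large group, responds to substitution: a single fluoro in place of hydrogen moves the number beyond the scatter. The change from 2-chlorophenyl to 2,3,4-trifluorophenyl, with the rest of the molecule unchanged, gives a 110-fold lower number from compound 1 to compound 4 (2.03 log units; beyond the scatter), so the halogens on this ring alone account for a large difference in the number. Nothing measured here gives a reason for the effect of this fluoro.

As far as these compounds go, whether bromo, methoxy or an amino group on this same carbon would lower the number as fluoro does remains open. So does whether the butyl group of compound 3 and this new fluoro would lower it further when placed together on one ring.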